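This account rests on a few compounds, and the source may have more. Where it says the series, first, only, none or still open, it means among the compounds named here.

The series shares one core, shown in compound 1 `Nc1nc(-c2ccc(C(F)F)o2)nc2sc(CN3CCC(F)CC3)cc12`, which carries a difluoromethyl-furan where the other compounds carry a substituted phenyl ring. In an assay on CHO-K1 cells for antagonist activity at adenosine receptor A1 (Homo sapiens), read by a beta-galactosidase reporter, with stated times of 15 min and 6 h (on this read-out higher numbers stand for weaker inhibition and lower numbers for stronger inhibition), compound 1 gives 1670 nM. Compound 2 `CS(=O)(=O)c1cccc(-c2nc(N)c3cc(CN4CCC(F)CC4)sc3n2)c1` bears a methylsulfonyl on that phenyl ring. In this assay compound 2 reaches only the limit of the measurement, > 10000 nM. Compound 3 `CN(C)C(=O)c1cccc(-c2nc(N)c3cc(CN4CCC(F)CC4)sc3n2)c1` bears a dimethylcarbamoyl in the same place. In this assay compound 3 likewise stops at the limit, > 10000 nM. The step that the two limits leave unreadable from compound 2 to compound 3 therefore has no readable size, as both ends rest on (the limit of > 10000 nM in this assay, at which 2 of the 3 values shown sit). Compound 3 thus stands without a number of its own, alongside compound 2 and clearly weaker than compound 1.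

Compound 4 `COc1cccc(-c2nc(N)c3cc(CN4CCC(F)CC4)sc3n2)c1` differs from compound 3 in one place: methoxy in place of dimethylcarbamoyl on an aromatic carbon. Among the measured compounds shown here, no measured step involves a methoxy, and the only step among the phenyl compounds cannot be sized, so the expectation rests on the gap between compound 1 and the two limits alone. For compound 4 an inhibition constant of 4000 nM is expected in this assay, between 800 nM and 20000 nM, so that the step of an at least 2.5-fold lower number from compound 3 to compound 4 (0.39 log units; beyond the scatter) is expected to stay unreadable, with a fair chance that compound 4 again only reaches the limit.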

Compound 4, inhibition constant: 3220 nM
The estimate for compound 4 lay 1.2-fold (0.09 log units) above the measured number; the measured number falls inside the stated range.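

With methoxy on this aromatic carbon, the phenyl compounds reach their first readable number in this assay: the change gives an at least 3.1-fold lower number from compound 3 to compound 4 (0.49 log units; beyond the scatter) and an at least 3.1-fold lower number from compound 2 to compound 4 (0.49 log units; beyond the scatter), which shows that the group in this place decides whether a value can be read at all. Both sizes are only lower bounds, not measured distances, since the two starting compounds rest on a limit: the limit of > 10000 nM in this assay, at which 2 of the 4 values shown sit.

The swap of the whole aromatic group gives a 1.9-fold higher number from compound 1 to compound 4 (0.29 log units; within the scatter), so 3-methoxyphenyl and 5-(difluoromethyl)furan-2-yl cannot be told apart in this assay, and the phenyl ring as such does not hold the number at the limit.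

As far as these compounds go, it remains open whether this result is particular to methoxy or would extend to a hydroxyl, an ethoxy chain or a fluorine in the same place. From the compounds shown here alone, the true sizes of the steps that start from the limits also stay open, as does the question of whether a methoxy on another carbon of the ring would give a similar number.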